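Methoxy for chloro in two amides of a benzoxaborole

The compounds below may be only part of what the source reports. "The series", "measured", "known", "first", "only" and "open" are said of these compounds alone.

Of the compounds shown here, three have been measured and a fourth has not. Compound 1 `O=C(CCc1cccc2c1B(O)OC2)Nc1ccc(Cl)cc1` and compound 2 `COc1ccc(NC(=O)CCc2cccc3c2B(O)OC3)cc1` share one core, while compound 3 `O=C(CCc1cccc2c1B(O)OC2)Nc1cccc(-c2ccc(Cl)cc2)c1` and compound 4 `COc1ccc(-c2cccc(NC(=O)CCc3cccc4c3B(O)OC4)c2)cc1` share another; the difference between the two cores is not broken down here. In an ADME assay on WI-38 cells (Homo sapiens) for cytotoxicity, read by MTT assay, with a stated time of 72 h (a higher number here means a weaker inhibitor, a lower number a stronger inhibitor), compound 1 gives > 100000 nM, which is a limit of the assay rather than a number. Compound 2 likewise gives > 100000 nM in this assay, again a limit. Because of the limit of > 100000 nM in this assay, at which 2 of the 3 values shown sit, the step that the two limits leave unreadable from compound 1 to compound 2 cannot be read. The change there is methoxy in place of chloro on an aromatic carbon. Compound 3, in this assay, gives 9800 nM. The same change is now made on that core: methoxy in place of chloro on an aromatic carbon. Since the earlier step left no readable size, the expectation for compound 4 rests only on compound 3 and its value 9800 nM, and the step from compound 3 to compound 4 is expected to be a 2.0-fold higher number from compound 3 to compound 4 (0.31 log units; beyond the scatter). Compound 4 is therefore estimated at 20000 nM, between 6000 nM and 100000 nM.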

Compound 4, half-maximal inhibitory concentration: 1400 nM
For compound 4 the middle estimate is 14-fold (1.15 log units) above the measured one; the measured number lies below the stated range.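

On the second of the two cores, methoxy in place of chloro gives a 7.0-fold lower number from compound 3 to compound 4 (0.85 log units; beyond the scatter) in this assay. A lower number in this cell test means more harm to the cells, so on this core the 4-methoxyphenyl compound is the more toxic of the pair, and the step is real but rests on a single pair of compounds. It does not show that the change carries from one core to the other, in size or even in direction, because the step on the first core cannot be read, and a limit gives no size to compare with: the limit of > 100000 nM in this assay, at which 2 of the 4 values shown sit.

The compounds shown leave open how other groups at this same place, such as an amine or a carboxylic acid, would behave on either core. Within the data shown here, they also leave open whether the lower number seen with methoxy would appear on any further core, since only one readable step exists so far.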